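Amide substituent variation on the sulfonamide series

A few compounds are considered here, and "the series" means these few. Any claim that something is new, unique, unknown or untested is made for them only; others in the source may bear on it.

Of the compounds shown here, two have been measured in an assay on isolated protein for displacement of a labelled ligand from secreted frizzled-related protein 1 (Homo sapiens), read by fluorescence polarization, with a stated time of 30 min; on this read-out higher numbers stand for weaker inhibition and lower numbers for stronger inhibition. Compound 1 `O=C(c1ccccc1)N1CCC(NS(=O)(=O)c2cc(S(=O)(=O)c3ccccc3)ccc2C(F)(F)F)CC1` carries phenyl on the carbonyl carbon and in this assay compound 1 gives 70 nM. Compound 2 `O=C(CC1CCNCC1)N1CCC(NS(=O)(=O)c2cc(S(=O)(=O)c3ccccc3)ccc2C(F)(F)F)CC1` carries (piperidin-4-yl)methyl at the same carbonyl carbon, and in this assay compound 2 gives 100 nM. The single step connecting them, a 1.4-fold higher number from compound 1 to compound 2 (0.15 log units; within the scatter), lies within the scatter, so compound 2 and compound 1 stand together on the numbers shown and neither can be separated from the other.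

Compound 3 `O=C([C@H]1CCNC1)N1CCC(NS(=O)(=O)c2cc(S(=O)(=O)c3ccccc3)ccc2C(F)(F)F)CC1` is the next member and is not yet measured. It differs from compound 2 in one place: pyrrolidin-3-yl in place of (piperidin-4-yl)methyl on a carbonyl carbon. Going by the values given here, the only measured step that bears on this position is a 1.4-fold higher number from compound 1 to compound 2 (0.15 log units; within the scatter), which shows that exchanging phenyl for a saturated amine-bearing substituent on the carbonyl carbon left the number essentially unchanged. On that basis the step of a 1.1-fold higher number from compound 2 to compound 3 (0.04 log units; within the scatter) is expected to stay within the scatter, with no direction beyond it. Compound 3 is therefore estimated at 110 nM in this assay, with a range from 45 nM to 280 nM.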

Compound 3, half-maximal inhibitory concentration in the secreted frizzled-related protein 1 assay: 40 nM
The estimate for compound 3 lay 2.8-fold (0.44 log units) above the measured number; measured number outside the range, below it.
By their numbers in the secreted frizzled-related protein 1 assay, from the lowest: compounds 3, 1 and 2 (each within the scatter of the next, the first and the last beyond it).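

In the secreted frizzled-related protein 1 assay the exchange of (piperidin-4-yl)methyl for pyrrolidin-3-yl on a carbonyl carbon gives a 2.5-fold lower number from compound 2 to compound 3 (0.40 log units; beyond the scatter), so this position does respond to a change among saturated amine-bearing substituents, which the step from phenyl had not shown. Going by these compounds alone, in the secreted frizzled-related protein 1 assay the exchange of phenyl for pyrrolidin-3-yl gives a 1.8-fold lower number from compound 1 to compound 3 (0.24 log units; within the scatter), so these two substituents cannot be separated, and only the pair of saturated substituents is resolved. In a physicochemical assay for solubility (a lower number here means a less soluble compound, a higher number a more soluble compound), compound 2 gives 100000 nM and compound 3 gives 25000 nM. The better number in the secreted frizzled-related protein 1 assay comes with a less soluble compound, so the change carries a cost in the physicochemical assay: the measured solubility of compound 2, 100000 nM, and of compound 3, 25000 nM, a 4.0-fold lower number (0.60 log units; beyond the scatter)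

The change alters ring size and the link to the carbonyl carbon together, so piperidin-4-yl attached directly to the carbonyl carbon would be needed to tell which of the two matters. Whether the defined stereocentre of compound 3 contributes also stays open, as the opposite configuration of pyrrolidin-3-yl is absent from the compounds shown, and so is an acetyl group on the ring nitrogen, which would show whether the free amine is required.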